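Switching the ortho substituent on the sulfonyl aryl group

The source may report more compounds than this note shows. Statements on the series, on what has been measured and on what is new or still open speak of the compounds shown alone.

Measured compounds:
compound 1 `CC1=NC(c2cn(S(=O)(=O)c3cccs3)c3ccc(C)cc23)CN1` gives 22000 nM in an assay on isolated protein for inhibition of kallikrein-7 (Mus musculus), read by fluorescence, with stated times of 10 min and 30 min; a lower number here means a stronger inhibitor, a higher number a weaker inhibitor
compound 2 `CC1=NC(c2cn(S(=O)(=O)c3ccccc3F)c3ccc(C)cc23)CN1` gives 6400 nM in this assay

Compound 2 holds the lowest of the two numbers in this assay; its nearest neighbour is compound 1, and the step of a 3.4-fold lower number from compound 1 to compound 2 (0.54 log units; beyond the scatter) was modest but beyond the scatter. Compound 3 `CC1=NC(c2cn(S(=O)(=O)c3ccccc3C)c3ccc(C)cc23)CN1` has not been measured. It differs from compound 2 in one place: methyl in place of fluoro on an aromatic carbon. Going by the values given here, no measured step repeats this change; the one step that bears on it, a 3.4-fold lower number from compound 1 to compound 2 (0.54 log units; beyond the scatter), only shows that the aryl group on the sulfonyl sulfur can move the number by a modest amount. With nothing closer to go on, the expected step of a 1.1-fold lower number from compound 2 to compound 3 (0.03 log units; within the scatter) is small, likely within the scatter, and compound 3 is estimated at 6000 nM, with a range of 2000 nM to 20000 nM.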

Compound 3, half-maximal inhibitory concentration: 1300 nM
The estimate for compound 3 lay 4.6-fold (0.66 log units) above the measured number, and the stated range ends above it.
By their numbers in this assay, from the lowest: compound 3; then compound 2; then compound 1.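

In this assay, the change from 2-fluorophenyl to 2-methylphenyl gives a 4.9-fold lower number from compound 2 to compound 3 (0.69 log units; beyond the scatter) and so shows that this one position on the six-membered aromatic ring responds to the exchange of a single heavy atom, something the earlier pair could not show. It also widens the range seen for the aryl group on the sulfonyl sulfur, with a 17-fold lower number from compound 1 to compound 3 (1.23 log units; beyond the scatter) as a large step where the earlier change of that group was only modest. No measurement at hand bears on why methyl and fluoro differ here. Still open, going by these compounds, is whether an ethyl, a methoxy or an amine in the same place would lower the number further or raise it. Also open, on these data alone, is whether methyl would have a similar effect on another carbon of that ring.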